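The compounds below may be only part of what the source reports. "The series", "measured", "known", "first", "only" and "open" are said of these compounds alone.

Working notes on the series, which varies the group on the nitrogen of the shared core. In a functional assay on the whole organism with Mus musculus as the target (a lower number here means that less compound is needed, a higher number that more compound is needed for the effect), compound 1 (`Cc1c(C)c2c(c(C)c1NC=O)CC(C)(C)O2`), the formyl member, gives > 100 mg/kg, which is a limit of the assay and not a number. Compound 2 (`CNc1c(C)c(C)c2c(c1C)CC(C)(C)O2`), the methyl member, gives 16.6 mg/kg. Compound 3 (`CCNc1c(C)c(C)c2c(c1C)CC(C)(C)O2`), the ethyl member, gives 38.9 mg/kg, the higher of the two actual numbers in this assay.

Next is compound 4 (`Cc1c(C)c2c(c(C)c1Nc1ccc(Cl)cc1)CC(C)(C)O2`), with 4-chlorophenyl in place of ethyl on a nitrogen on an aromatic ring. No aryl group on this nitrogen has been measured, so the evidence is indirect. Among the compounds with values here, the closest guide is a 2.3-fold higher number from compound 2 to compound 3 (0.37 log units; beyond the scatter), a modest step and the only one between two actual numbers. Replacing formyl also changed the number, giving an at least 6.0-fold lower number from compound 1 to compound 2 (0.77 log units; beyond the scatter) and an at least 2.5-fold lower number from compound 1 to compound 3 (0.41 log units; beyond the scatter), so the group on this nitrogen matters in this assay. Those two steps start from a limit and involve a different kind of change.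

Extending the direction seen from compound 2 to compound 3, a modest rise is expected, though with low confidence. The expected size is a 2.1-fold higher number from compound 3 to compound 4 (0.31 log units; beyond the scatter). For compound 4 the estimated value is 80 mg/kg, with an expected range from 25 mg/kg to 200 mg/kg.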

Compound 4, dose for 50% inhibition: > 50 mg/kg
Compound 4: a limit, no number; the forecaster's own chance of this, stated with the estimate: 35%; the middle value lies beyond the limit too.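

In this assay, within the data shown here, compound 4 gives a limit and not a number, so the first aryl group on this nitrogen can be read only as a floor: the limit of > 50 mg/kg in this assay, at which 1 of the 4 values shown sits. Among these compounds, the floor is informative against the methyl member, with an at least 3.0-fold higher number from compound 2 to compound 4 (0.47 log units; beyond the scatter), so 4-chlorophenyl on this nitrogen needs more compound than methyl does, a separation that the earlier compounds could not show for an aryl group. Against the ethyl member the result is much weaker, with an at least 1.2-fold higher number from compound 3 to compound 4 (0.10 log units; that floor lies within the scatter), so no order between ethyl and 4-chlorophenyl can be claimed, and the step that starts from the formyl member cannot be read, with limits on both sides.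

The compounds shown leave open how far the real number of compound 4 lies from its limit, and whether the chlorine or the aromatic ring itself accounts for the result. An unsubstituted phenyl, a propyl chain or the free amine on the shared core would test these points and show whether the change from methyl to ethyl extends to longer chains.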